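A benzyl change tested on a potent semicarbazide series

A few compounds are considered here, and "the series" means these few. Any claim that something is new, unique, unknown or untested is made for them only; others in the source may bear on it.

Three close relatives have been measured in an assay on CHO cells for displacement of a labelled ligand from D(4) dopamine receptor (Homo sapiens), read by radioligand binding; on this read-out lower numbers stand for stronger inhibition and higher numbers for weaker inhibition. Compound 1 `COc1ccccc1N1CCN(CCCNC(=O)NN(Cc2ccccc2F)c2ccc(F)cc2)CC1` gives 3.6 nM. Compound 2 `COc1ccccc1N1CCN(CCCNC(=O)NN(Cc2ccccc2F)c2ccc(Cl)cc2)CC1` gives 2.6 nM, and compound 3 `COc1ccc(N(Cc2ccccc2F)NC(=O)NCCCN2CCN(c3ccccc3OC)CC2)cc1` gives 2.6 nM. These three differ only in the group on the aromatic ring attached to the nitrogen: the step of a 1.4-fold lower number from compound 1 to compound 2 (0.14 log units; within the scatter) and the step of a 1.4-fold lower number from compound 1 to compound 3 (0.14 log units; within the scatter) are both within the scatter, and the step of no change at the digits printed from compound 2 to compound 3 (within the scatter) is as well. Compound 3 therefore sits level with compound 2 and, on the numbers shown, no compound can be called stronger than another.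

Compound 4 `COc1ccc(N(Cc2ccc(C#N)cc2)NC(=O)NCCCN2CCN(c3ccccc3OC)CC2)cc1` leaves that ring alone and instead alters the other arm on the same nitrogen: 4-cyanophenyl in place of 2-fluorophenyl on a saturated chain carbon bound to a nitrogen on an aromatic ring. For the measured compounds named here, none of the measured steps touches this benzyl group, so they give no direct guide; they only show that the shared core has so far tolerated small changes elsewhere without moving beyond the scatter. A change of a substituent and of its place on the benzyl ring is less predictable, and a modest weakening is the cautious expectation. The expected step is a 2.3-fold higher number from compound 3 to compound 4 (0.36 log units; beyond the scatter), and compound 4 is estimated at 6 nM, with a likely range from 2 nM to 25 nM in this assay.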

Compound 4, inhibition constant: 16 nM
The estimate for compound 4 lay 2.7-fold (0.43 log units) below the measured number; low and high end bracket the measured number.
By their numbers in this assay, from the lowest: compounds 2, 3 and 1 (each within the scatter of the next); then compound 4.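

In this assay, for the compounds shown here, the benzyl arm proves more sensitive than the earlier compounds suggested: replacing 2-fluorobenzyl with 4-cyanobenzyl gives a 6.2-fold higher number from compound 3 to compound 4 (0.79 log units; beyond the scatter), the first step in this small set to go beyond the scatter, whereas all three changes on the other aromatic ring stayed within it. The weakening is modest, however, since compound 4 still binds at 16 nM, so the receptor tolerates this new group to a useful degree. The swap removes a fluoro group and brings in a nitrile on a differently numbered ring position, so this single step cannot separate those changes, and no measurement here explains the shift.

On these data alone, it remains open whether the weaker binding follows from losing the fluoro group or from adding the nitrile, a question that a plain benzyl group with no substituent, or a carboxylic acid in place of the nitrile, could help to answer. It is also unknown whether 4-cyanobenzyl would cost a similar amount on the fluoro and chloro relatives, compound 1 and compound 2.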